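The source may hold more compounds than are shown below. What is called first, only, known or untested is meant among the compounds shown, and "the series" means these compounds.

Measured in an ADME assay on microsomes from liver (Mus musculus, strain CD1) for metabolic stability, with a stated time of 1 h; on this read-out lower numbers stand for a less stable compound and higher numbers for a more stable compound:
- compound 1 `O=[N+]([O-])c1cn2c(n1)[S@+]([O-])C[C@H](OCc1ccc(OC(F)(F)F)cc1)C2`: 89%
- compound 2 `O=[N+]([O-])c1cn2c(n1)[S@@+]([O-])C[C@H](OCc1ccc(OC(F)(F)F)cc1)C2`: 26%

Compound 2 stands lowest of these two, with compound 1 well above it, beyond the scatter. Compound 3 `O=[N+]([O-])c1cn2c(n1)[S@+]([O-])C[C@@H](OCc1ccc(OC(F)(F)F)cc1)C2` follows from compound 2: the two compounds have the same atoms and bonds and differ only in configuration as drawn: 2 of 2 stereo elements differ (all stereocentres are inverted: mirror images); a stereocentre at a sulfur is drawn S in compound 2 and R in compound 3; a stereocentre at a saturated ring carbon is drawn R in compound 2 and S in compound 3. Among the measured compounds shown here, the one measured step bearing on this is a number 63 percentage points lower from compound 1 to compound 2 (beyond the scatter), which is due to the fact that compounds 1 and 2 differ only in the configuration as drawn. That step took the sulfur from R to S. Here the sulfur goes back from S to R, while the ring carbon, which no measurement covers, inverts too. A rise beyond the scatter is therefore expected, smaller than that large drop, as a number 32 percentage points higher from compound 2 to compound 3 (beyond the scatter) in this assay. The estimate for compound 3 is 58%, expected between 30% and 88%.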

Compound 3, percent of the compound remaining: 96%
Compound 3: the middle estimate sits 38 percentage points below what was measured; measured number outside the range, above it.
By their numbers in this assay, from the lowest: compound 2; then compounds 1 and 3 (each within the scatter of the next).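

In this assay, inverting the saturated ring carbon alone, with the sulfur kept R, gives a number 7 percentage points higher from compound 1 to compound 3 (within the scatter), whereas inverting both stereocentres gives a number 70 percentage points higher from compound 2 to compound 3 (beyond the scatter). Among these three compounds, the sulfur drawn R therefore goes with the high numbers whichever way the ring carbon is drawn, and the ring carbon alone shifts nothing beyond the scatter. The large rise is due to configuration alone: the fact that compounds 2 and 3 differ only in the configuration as drawn

Still open, going by these compounds, is whether the sulfur drawn S gives a low number with the ring carbon drawn S as well. Also open, on these data alone, is whether this gap between the sulfur forms holds if a nitrile or an amine replaces the trifluoromethoxy group.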